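Replacing 6-methoxypyridin-3-yl in compound 3

A few compounds are considered here, and "the series" means these few. Any claim that something is new, unique, unknown or untested is made for them only; others in the source may bear on it.

In a functional assay on SMMC-7721 cells (Homo sapiens) for inhibition, read by MTT assay, with a stated time of 48 h (a lower number here means a stronger inhibitor, a higher number a weaker inhibitor), compound 3 `COc1ccc(-c2cc(NC(=O)Nc3nccs3)cc(C(F)(F)F)c2)cn1` gives 36200 nM, within the scatter of compound 2 `O=C(Nc1cc(-c2cccnc2)cc(C(F)(F)F)c1)Nc1nccs1` at 68200 nM. Compound 1 `O=C(Nc1ccncc1)Nc1cc(-c2cncnc2)cc(C(F)(F)F)c1` gives 3730 nM, and the gap between compound 3 and this number lies beyond the scatter.

Compound 4 `O=C(Nc1cc(-c2cncnc2)cc(C(F)(F)F)c1)Nc1nccs1` carries pyrimidin-5-yl in place of 6-methoxypyridin-3-yl on an aromatic carbon. Going by the values given here, the only measured step touching this group is a 1.9-fold lower number from compound 2 to compound 3 (0.28 log units; within the scatter), with methoxy in place of hydrogen on an aromatic carbon, and it stays within the scatter. Compound 4 differs elsewhere from compound 1, which already carries pyrimidin-5-yl, so compound 1 at 3730 nM is weak guidance. The data hold no direct comparison of pyrimidin-5-yl with a pyridine group on an otherwise identical structure.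

No change beyond the scatter is therefore expected, with a slightly lower number at most. The expected change is a 1.1-fold lower number from compound 3 to compound 4 (0.05 log units; within the scatter). For compound 4 the estimated value is 32000 nM, with an expected range of 11000 nM to 80000 nM.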

Compound 4, half-maximal inhibitory concentration: 29700 nM
For compound 4 the middle estimate is 1.1-fold (0.03 log units) above the measured one; low and high end bracket the measured number.
By their numbers in this assay, from the lowest: compound 1; then compounds 4, 3 and 2 (each within the scatter of the next, the first and the last beyond it).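

In this assay, the step of a 1.2-fold lower number from compound 3 to compound 4 (0.09 log units; within the scatter) shows that pyrimidin-5-yl and 6-methoxypyridin-3-yl cannot be told apart at this position, on the aromatic carbon meta to the trifluoromethyl group. Against pyridin-3-yl, however, the step of a 2.3-fold lower number from compound 2 to compound 4 (0.36 log units; beyond the scatter) passes the scatter, though only modestly, while the step of an 8.0-fold higher number from compound 1 to compound 4 (0.90 log units; beyond the scatter) with pyrimidin-5-yl held constant is larger and places more of the range in the group on the amide-type nitrogen than in this ring. Nothing available explains any of these steps.

Open, as far as these compounds go, is whether pyridin-4-yl on the amide-type nitrogen keeps its lower number with 6-methoxypyridin-3-yl or pyridin-3-yl at this position. Also open, from the compounds shown here alone, is how an amine or a carboxylic acid on this aromatic carbon would compare with the three rings.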